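A Methyl on the Amine: From Compound 1 to Compound 4

This account rests on a few compounds, and the source may have more. Where it says the series, first, only, none or still open, it means among the compounds named here.

Compound 1 `CNCc1ccc(-n2c(SC(C)c3ccccc3)nc3c(cnn3C)c2=O)cc1` — 70%
Compound 2 `CC(Oc1nc2c(cnn2C)c(=O)n1-c1ccccc1)c1ccccc1` — 42%
Compound 3 `COc1ccc(C(C)Sc2nc3c(cnn3C)c(=O)n2-c2ccccc2)cc1` — 41%

In an assay on isolated protein for inhibition of retinal dehydrogenase 2 (Homo sapiens), tested at 5 uM (a lower number here means less inhibition, a higher number more inhibition at the concentration tested (going by the name of the read-out)), compound 1 gives 70%, the highest of the three numbers. Compound 2 gives 42%, and compound 3 gives 41%; both lie below compound 1 by more than the scatter. Compound 4 `CC(Sc1nc2c(cnn2C)c(=O)n1-c1ccc(CN(C)C)cc1)c1ccccc1` is compound 1 with a single change: methyl in place of hydrogen on an amine nitrogen. Among the compounds with values here, no pair of measured compounds shares this change, so the data give no measured step of this kind to lean on. I expect only a small move from compound 1, a step of a number 5 percentage points lower from compound 1 to compound 4 (within the scatter) that stays within the scatter, with no clear direction. Compound 4 is therefore estimated at 65%, within a range from 45% to 85%.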

Compound 4, a percentage reported as inhibition, at one concentration (the size of the read-out at that concentration, not a potency): 86%
The estimate for compound 4 lay 21 percentage points below the measured number, outside the stated range (above it).
By their numbers in this assay, from the lowest: compounds 3 and 2 (each within the scatter of the next); then compound 1; then compound 4.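

In this assay, the change from methylamino to dimethylamino gives a number 16 percentage points higher from compound 1 to compound 4 (beyond the scatter). The amine nitrogen is therefore a place where replacing hydrogen with methyl raises the number instead of lowering it, and a single added carbon is enough to move it beyond the scatter. No measurement at hand accounts for this rise. Going by these compounds, what remains open is how the number responds to a larger group on this nitrogen, such as ethyl, or to a ring amine such as pyrrolidine. An amide in place of the amine is equally untested in the compounds shown.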